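The source may hold more compounds than are shown below. What is called first, only, known or untested is meant among the compounds shown, and "the series" means these compounds.

Compound 3 `CCS[C@@H]1[C@H](SCC)[C@@H](Cn2cc(-c3cccc(C)c3)nn2)O[C@H]1n1ccc(=O)[nH]c1=O` carries a 3-methylphenyl on the five-membered ring of the shared core. In a functional assay on HeLa cells (Homo sapiens) for cytotoxicity, read by MTT assay, with a stated time of 72 h (a lower number here means that less compound is needed, a higher number that more compound is needed for the effect), compound 3 gives 18800 nM, which places it second highest among the three measured compounds. Its nearest neighbour is compound 2 `CCS[C@@H]1[C@H](SCC)[C@@H](Cn2cc(-c3ccc(F)cc3)nn2)O[C@H]1n1ccc(=O)[nH]c1=O`, which in this assay gives 37400 nM; the gap, a 2.0-fold lower number from compound 2 to compound 3 (0.30 log units; within the scatter), lies within the scatter, so the two cannot be set in order. Compound 1 `CCS[C@@H]1[C@H](SCC)[C@@H](Cn2cc(-c3ccccc3)nn2)O[C@H]1n1ccc(=O)[nH]c1=O`, the unsubstituted phenyl parent, gives 6590 nM in this assay and lies furthest from compound 3, as a 2.9-fold higher number from compound 1 to compound 3 (0.46 log units; beyond the scatter) shows.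

Compound 4 `CCS[C@@H]1[C@H](SCC)[C@@H](Cn2cc(COC(C)=O)nn2)O[C@H]1n1ccc(=O)[nH]c1=O` differs from compound 3 in one place: acetoxymethyl in place of 3-methylphenyl on an aromatic carbon. For the measured compounds named here, no measured step removes the aromatic ring; the two steps that exist, a 5.7-fold higher number from compound 1 to compound 2 (0.75 log units; beyond the scatter) and a 2.9-fold higher number from compound 1 to compound 3 (0.46 log units; beyond the scatter), only alter a substituent on that ring, and both are modest in size. Going by the values given here, they bear on the new step only as a gauge of how much a change at this position has moved the number so far. With the ring itself gone, the direction is open, and a step of modest size in either direction in this assay is the most that can be expected. Compound 4 is therefore estimated at 30000 nM, with a range from 8000 nM to 120000 nM, meaning an expected step of a 1.6-fold higher number from compound 3 to compound 4 (0.20 log units; within the scatter).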

Compound 4, half-maximal effective concentration: >= 100000 nM
Compound 4 ended at the assay's limit; the forecaster's own chance of this, stated with the estimate: 25%; middle value at least 3.3-fold (0.52 log units) from the limit.
By their numbers in this assay, from the lowest: compound 1; then compounds 3 and 2 (each within the scatter of the next). At a limit, above all of these: compound 4.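

In this assay compound 4 gives no number, only a limit: the limit of >= 100000 nM in this assay, at which 1 of the 4 values shown sits.

The earlier compounds shown here changed only a substituent on the aromatic ring, whereas here the whole ring gives way to acetoxymethyl on the same carbon of the five-membered aromatic ring, and the readable steps are an at least 5.3-fold higher number from compound 3 to compound 4 (0.72 log units; beyond the scatter), an at least 2.6-fold higher number from compound 2 to compound 4 (0.42 log units; beyond the scatter) and an at least 15-fold higher number from compound 1 to compound 4 (1.18 log units; beyond the scatter). All three lie beyond the scatter, and the last is large, so this position shows a change that the substituent steps had not: among the four compounds shown, the three that carry an aromatic ring here all give lower numbers than the one that carries none.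

The compounds shown leave open whether this shift follows the loss of the aromatic ring or the entry of the acetoxymethyl group, as the two happen together in every step to compound 4. A hydroxymethyl group, a plain butyl chain or a pyridine ring on this carbon would bear on that question, and so would a phenyl ring carrying an amine.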